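The source may hold more compounds than are shown below. What is called first, only, known or untested is meant among the compounds shown, and "the series" means these compounds.

Of the compounds shown here, three have so far been tested in an in vitro assay on BHK cells for displacement of a labelled ligand from gastric inhibitory polypeptide receptor (Homo sapiens), read by scintillation proximity assay; a higher number here means a weaker inhibitor, a lower number a stronger inhibitor. Compound 1, `O=C(O)CCNC(=O)c1ccc(CC(c2ccc(Cl)cc2)c2nc(-c3ccc(C(F)(F)F)cc3)cs2)cc1`, gives 381 nM in this assay. Compound 3, `O=C(O)CCNC(=O)c1ccc(CC(c2ccc(Cl)cc2)c2nc(-c3ccc(OC(F)(F)F)cc3)cs2)cc1`, carries a different group on its outer ring: trifluoromethoxy in place of trifluoromethyl on an aromatic carbon. In this assay compound 3 gives 429 nM, and the step of a 1.1-fold higher number from compound 1 to compound 3 (0.05 log units; within the scatter) shows that swapping trifluoromethyl for trifluoromethoxy here changed essentially nothing.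

Compound 2, `O=C(O)CCNC(=O)c1ccc(CN(c2ccc(Cl)cc2)c2nc(-c3ccc(C(F)(F)F)cc3)cs2)cc1`, has a different core from compound 1; the difference between the two cores is not broken down here. In this assay compound 2 gives 649 nM, a number that sits within the usual scatter of those for compound 1 and compound 3, so nothing can be said about which of the three is the stronger binder.

Compound 4, `O=C(O)CCNC(=O)c1ccc(CN(c2ccc(Cl)cc2)c2nc(-c3ccc(OC(F)(F)F)cc3)cs2)cc1`, has not yet been measured. It relates to compound 2 exactly as compound 3 relates to compound 1: trifluoromethoxy in place of trifluoromethyl on an aromatic carbon. The position and surroundings of the exchanged group are described in the same words in both pairs, so this is the same change carried over to the core of compound 2.

For compound 4 a step of about a 1.1-fold higher number from compound 2 to compound 4 (0.05 log units; within the scatter) is expected from compound 2, resting on the earlier step of a 1.1-fold higher number from compound 1 to compound 3 (0.05 log units; within the scatter), which was within the scatter. The value of compound 4 in this assay is therefore estimated at 720 nM, with a plausible range from 350 nM to 1500 nM.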

Compound 4, half-maximal inhibitory concentration: 869 nM
Compound 4: the middle estimate sits 1.2-fold (0.08 log units) below what was measured, and the stated range covers the measured number.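

In this assay the exchange of trifluoromethyl for trifluoromethoxy on the core of compound 2 gives a 1.3-fold higher number from compound 2 to compound 4 (0.13 log units; within the scatter) and so, on this core as well, leaves a difference that cannot be told apart from the ordinary spread of repeated measurements. The exchange therefore carried over from one core to the other without any visible shift, and the two steps agree as far as this assay can tell: the same change on two cores in this assay, a 1.1-fold higher number (0.05 log units; within the scatter) from compound 1 to compound 3 and a 1.3-fold higher number (0.13 log units; within the scatter) from compound 2 to compound 4, 1.2-fold (0.08 log units) apart, within the scatter of two such steps. Among these compounds, this shows only that the two groups could not be told apart on these two cores, in this one assay; it does not show that they behave alike on any other core, and steps this small cannot reveal whether a slight real difference lies hidden in the scatter.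

The compounds shown leave open whether a group such as a nitrile or a methyl group, placed where trifluoromethyl sits, would also carry over unchanged between the two cores. They also leave open what an amine or a longer chain in place of the carboxylic acid end would do on either core.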